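The source may hold more compounds than are shown below. What is called first, only, known or untested is meant among the compounds shown, and "the series" means these compounds.

Compound 1 `O=C1/C(=C/c2cccc(F)c2)CCc2ccccc21`: 31100 nM
Compound 2 `O=C1CCCCC/C1=C\c1cccc(Cl)c1`: 25700 nM

Among the measured compounds shown here, both compounds were tested in a functional assay on P388 cells (Mus musculus) for inhibition (a lower number here means a stronger inhibitor, a higher number a weaker inhibitor), and so far they are the only two with a measured value. Compound 2 stands at 25700 nM, within the scatter of compound 1 at 31100 nM. For the measured compounds named here, the two values therefore set no order between the compounds.

Compound 3 `O=C1CCCCC/C1=C\c1cccc([N+](=O)[O-])c1` is the next to be considered. It carries nitro in place of chloro on an aromatic carbon. Going by the values given here, no measured pair shows this change, so the expectation rests only on the two values in hand and has a wide margin. No shift beyond the scatter is expected, and the estimated change is a 1.2-fold lower number from compound 2 to compound 3 (0.07 log units; within the scatter). For compound 3 the expected value is 22000 nM, with an estimated range from 8000 nM to 60000 nM.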

Compound 3, half-maximal inhibitory concentration: 23600 nM
For compound 3 the middle estimate is 1.1-fold (0.03 log units) below the measured one, within the range that was stated.
By their numbers in this assay, from the lowest: compounds 3, 2 and 1 (each within the scatter of the next).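

Among the compounds shown here, compound 2 and compound 3 form the first pair here that differs in one place, and in this assay nitro in place of chloro gives a 1.1-fold lower number from compound 2 to compound 3 (0.04 log units; within the scatter) on this aromatic carbon. At this position, meta to a group of 9 heavy atoms, a group of 3 heavy atoms with 2 hydrogen-bond acceptors thus takes the place of a single chlorine with no step beyond the scatter. Nothing in hand offers an explanation for this result. The compounds shown leave open whether a group of another kind at this position, such as an amine, a carboxylic acid or a longer chain, would move the number beyond the scatter. They also leave open whether nitro in place of chloro would read the same on the core of compound 1.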